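A few compounds are considered here, and "the series" means these few. Any claim that something is new, unique, unknown or untested is made for them only; others in the source may bear on it.

Compound 3, whose structure is `CCCCNC(=O)NCc1ccc(CCCC)n(Cc2ccc(-c3ccccc3-c3nn[nH]n3)cc2)c1=O`, gives the lowest number of the three measured compounds in a functional assay on the whole organism (artery) for inhibition, with Rattus norvegicus as the target, at a dose of 3 mg/kg by the intraduodenal route; on this read-out lower numbers stand for less inhibition and higher numbers for more inhibition at the one dose given (going by the name of the read-out): it gives 10.3%, while compound 2, with the structure `CCCCc1ccc(CNC(=O)N(C)C)c(=O)n1Cc1ccc(-c2ccccc2-c2nn[nH]n2)cc1`, gives 28%, and compound 1, with the structure `CCCCc1ccc(CNC(=O)OC(C)(C)C)c(=O)n1Cc1ccc(-c2ccccc2-c2nn[nH]n2)cc1`, gives 68.9%. Both gaps lie beyond the scatter, so compound 3 stands at the bottom.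

Compound 4, with the structure `CCCCc1ccc(CN(C)S(C)(=O)=O)c(=O)n1Cc1ccc(-c2ccccc2-c2nn[nH]n2)cc1`, is not yet measured. The change from compound 3 to compound 4 is methyl(methylsulfonyl)amino in place of (butylcarbamoyl)amino on a saturated chain carbon bound to an aromatic carbon.

Every measured step alters the same part of the molecule, the group attached to the carbonyl carbon: a number 40.9 percentage points lower from compound 1 to compound 2 (beyond the scatter), a number 58.6 percentage points lower from compound 1 to compound 3 (beyond the scatter), and a number 17.7 percentage points lower from compound 2 to compound 3 (beyond the scatter). Going by the values given here, none of them replaces the carbonyl-bearing group as a whole by methyl(methylsulfonyl)amino, so no step matches the present change directly. What they do show is that changes at this position move this assay by large amounts in both directions. Compound 3 sits lowest, and the groups that differ from butylamino gave higher numbers in compounds 1 and 2, so a rise is more plausible than a further fall, though its size is uncertain.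

Compound 4 is therefore expected to show a number 24.7 percentage points higher from compound 3 to compound 4 (beyond the scatter), with an estimated value of 35%, the range running from 8% to 62%.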

Compound 4, a percentage reported as inhibition, in the whole organism at one dose (the size of the read-out at that dose, not a potency): 83.4%
Compound 4: middle estimate off by 48.4 percentage points, on the low side, outside the stated range (above it).
By their numbers in this assay, from the lowest: compound 3; then compound 2; then compound 1; then compound 4.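

The carbonyl-bearing groups are not needed for a high number at this saturated chain carbon: in this assay, methyl(methylsulfonyl)amino, which has no carbonyl and no hydrogen-bond donors, gives a number 73.1 percentage points higher from compound 3 to compound 4 (beyond the scatter) and a number 55.4 percentage points higher from compound 2 to compound 4 (beyond the scatter), both large steps. It also goes beyond the best of the carbonyl-bearing groups, (tert-butoxycarbonyl)amino, with a number 14.5 percentage points higher from compound 1 to compound 4 (beyond the scatter), a modest step but one beyond the scatter, so compound 4 holds the highest number of the four compounds in this assay. No measurement here explains why this replacement moves the read-out so far.

The compounds shown leave open which part of the new group carries the rise, since the methyl on the nitrogen and the methylsulfonyl enter together, and a plain methylsulfonylamino group with the hydrogen kept on the nitrogen would separate them. They also leave open how far the sulfonyl side tolerates change, for instance whether a butylsulfonyl chain or a phenylsulfonyl group in place of methylsulfonyl would hold the number in this assay or lose it.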